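Methylamino for methylsulfanyl in compound 2

The source may report more compounds than this note shows. Statements on the series, on what has been measured and on what is new or still open speak of the compounds shown alone.

Three compounds have numbers or limits in a functional assay on CEM-DNR-bulk cells (Homo sapiens), read by MTT assay, with a stated time of 72 h; on this read-out higher numbers stand for weaker inhibition and lower numbers for stronger inhibition. Compound 1 `COc1ncnc2c1c(-c1cc3ccccc3o1)cn2[C@@H]1O[C@H](CO)[C@@H](O)[C@H]1O` gives 10800 nM. Compound 3 `C#Cc1cn([C@@H]2O[C@H](CO)[C@@H](O)[C@H]2O)c2ncnc(SC)c12` gives 110 nM. Compound 2 `CSc1ncnc2c1c(-c1ccsc1)cn2[C@@H]1O[C@H](CO)[C@@H](O)[C@H]1O` returns only a limit, > 20000 nM. Compound 2 therefore has no exact value and stands at the limit of > 20000 nM in this assay, at which 1 of the 3 values shown sits.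

Compound 4 `CNc1ncnc2c1c(-c1ccsc1)cn2[C@@H]1O[C@H](CO)[C@@H](O)[C@H]1O` keeps the thiophen-3-yl group of compound 2 and carries methylamino in place of methylsulfanyl on an aromatic carbon.

For the measured compounds named here, only one measured step touches compound 2, and it lies elsewhere on the molecule. With ethynyl in place of thiophen-3-yl, the data show an at least 180-fold lower number from compound 2 to compound 3 (2.25 log units; beyond the scatter), a large step beyond the scatter, while methylsulfanyl stays in place. Going by the values given here, that step shows how far this assay can move, but it does not measure the exchange at hand, and no measured pair tests methylsulfanyl against methylamino. The thiophen-3-yl group also stays in compound 4, so a change on the scale of that large step is not expected. A moderate move toward a lower number is the cautious expectation, and another limit remains quite possible.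

The expected change is an at least 1.6-fold lower number from compound 2 to compound 4 (0.22 log units; that floor lies within the scatter). Compound 4 is estimated at 12000 nM, with an expected range of 2500 nM to 40000 nM.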

Compound 4, half-maximal inhibitory concentration: > 20000 nM
Compound 4 was reported as a limit (the forecaster's own chance of this, stated with the estimate: 45%); middle value at least 1.6-fold (0.22 log units) from the limit.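

Compound 2 and compound 4 both return only a limit in this assay, so the step between them cannot be read, and neither compound gives an exact value to compare: the limit of > 20000 nM in this assay, at which 2 of the 4 values shown sit. Whether methylamino in place of methylsulfanyl on this aromatic carbon moves the number at all stays open among the compounds shown.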